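A few compounds are considered here, and "the series" means these few. Any claim that something is new, unique, unknown or untested is made for them only; others in the source may bear on it.

Of the compounds shown here, three built on the same core have been tested in a functional assay on MCF7 cells (Homo sapiens) for inhibition, read by sulforhodamine B assay; on this read-out lower numbers stand for stronger inhibition and higher numbers for weaker inhibition. Compound 1 `Cc1ccc(NC2=CC(=O)c3c(nc4n3[C@H]3OC[C@@H](O)[C@H]3OC4)C2=O)cc1C` gives 4950 nM, the highest of the two numbers. Compound 2 `CCc1ccc(NC2=CC(=O)c3nc4n(c3C2=O)[C@H]2OC[C@@H](O)[C@H]2OC4)cc1` gives 960 nM. For compound 3 `O=C1C=C(Nc2ccc(C(F)(F)F)cc2)C(=O)c2c1nc1n2[C@H]2OC[C@@H](O)[C@H]2OC1` only a limit is reported, > 4000 nM. Among the compounds with values here, the single measured step changes the group on the amine nitrogen: an at least 4.1-fold higher number from compound 2 to compound 3 (0.61 log units; beyond the scatter). Compound 4 `O=C1C(Nc2cccc(F)c2)=CC(=O)c2c1nc1n2[C@H]2OC[C@@H](O)[C@H]2OC1` differs from compound 1 at that same place: 3-fluorophenyl in place of 3,4-dimethylphenyl on an amine nitrogen. Within the data shown here, that step shows the aryl group can shift the number, yet no measured pair exchanges 3,4-dimethylphenyl for 3-fluorophenyl, so the direction is uncertain. The expected step is a 1.2-fold lower number from compound 1 to compound 4 (0.09 log units; within the scatter), within the scatter. Compound 4 is therefore estimated at about 4000 nM, between 1500 nM and 12000 nM.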

Compound 4, half-maximal inhibitory concentration: > 4000 nM
Compound 4: no number, only a limit; the forecaster's own chance of this, stated with the estimate: 25%; the middle value sits exactly at the limit.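

Compound 4 gives only a limit of > 4000 nM and so the step from compound 1 cannot be read: the limit of > 4000 nM in this assay, at which 2 of the 4 values shown sit. The compounds shown leave open whether 3-fluorophenyl in place of 3,4-dimethylphenyl moves the number at all, and in which direction.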